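The source may report more compounds than this note shows. Statements on the series, on what has been measured and on what is new or still open speak of the compounds shown alone.

In a functional assay on HUVEC cells (Homo sapiens) for cytotoxicity (a lower number here means that less compound is needed, a higher number that more compound is needed for the effect), compound 1 `COC1=C(C)C(=O)/C(=C(O)/C=C/c2cccc(OC)c2)C(=O)C1(C)C` gives 1.6 ug/mL, compound 2 `COC1=C(C)C(=O)/C(=C(O)/C=C/c2ccc(C)cc2)C(=O)C1(C)C` gives 2.4 ug/mL and compound 3 `COC1=C(C)C(=O)/C(=C(O)/C=C/c2cc(C)cc(C)c2)C(=O)C1(C)C` gives 2.5 ug/mL. These numbers do not separate: a 1.5-fold higher number from compound 1 to compound 2 (0.18 log units; within the scatter), a 1.6-fold higher number from compound 1 to compound 3 (0.19 log units; within the scatter) and a 1.0-fold higher number from compound 2 to compound 3 (0.02 log units; within the scatter) all lie within the scatter, so compound 3 stands level with the other two.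

Compound 4 `COC1=C(C)C(=O)/C(=C(O)/C=C/c2nccs2)C(=O)C1(C)C` carries 1,3-thiazol-2-yl in place of 3,5-dimethylphenyl on a double-bonded chain carbon bound to a double-bonded chain carbon.

The three measured steps bear on this place in the structure, but only as exchanges among substituted phenyl groups. For the measured compounds named here, no measured compound has a ring with hetero atoms there, so the evidence for this change is indirect. On these steps, no change beyond the scatter is expected in this assay, and no direction can be assigned. The expected step is no change at the digits printed from compound 3 to compound 4 (within the scatter). Compound 4 is estimated at 2.5 ug/mL, with an expected range of 1 ug/mL to 6.5 ug/mL, kept wide for the untested ring type.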

Compound 4, concentration for half-maximal effect: 1.6 ug/mL
For compound 4 the middle estimate is 1.6-fold (0.19 log units) above the measured one; measured number inside the range.
By their numbers in this assay, from the lowest: compounds 1, 4, 2 and 3 (each within the scatter of the next).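

In this assay, a five-membered aromatic ring with hetero atoms, 1,3-thiazol-2-yl, reads level with all three substituted phenyl groups (a 1.6-fold lower number from compound 3 to compound 4 (0.19 log units; within the scatter); a 1.5-fold lower number from compound 2 to compound 4 (0.18 log units; within the scatter); no change at the digits printed from compound 1 to compound 4 (within the scatter)). The place on a double-bonded chain carbon bound to a double-bonded chain carbon therefore accepts more than substituted phenyl groups, with no step beyond the scatter across a change of ring size, heavy atoms and hydrogen-bond acceptors. No evidence is available to explain this level reading.

On these data alone, it remains open whether a pyridine ring, an amine or a carboxylic acid at this place would give a step beyond the scatter. Also open, as far as these compounds go, is whether any change to the shared core would separate these compounds in this assay.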